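The compounds below may be only part of what the source reports. "The series", "measured", "known", "first", "only" and "open" are said of these compounds alone.

Compound 1 `Cc1ccc(-c2nc3ccccn3c2Sc2ccccc2)cc1` gives 83300 nM
Compound 2 `Cc1ccc(-c2nc3ccc(C)cn3c2Sc2ccccc2)cc1` gives 57700 nM

In a functional assay on DU-145 cells (Homo sapiens) for inhibition, read by MTT assay, with a stated time of 48 h (a lower number here means a stronger inhibitor, a higher number a weaker inhibitor), compound 1 gives 83300 nM and has a single measured neighbour, compound 2, which lies within the scatter of it. Among the compounds with values here, the only measured step (a 1.4-fold lower number from compound 1 to compound 2 (0.16 log units; within the scatter)) is methyl in place of hydrogen on an aromatic carbon, and it stays within the scatter.

Compound 3 `N#Cc1ccc(-c2nc3ccccn3c2Sc2ccccc2)cc1` differs from compound 1 by cyano in place of methyl on an aromatic carbon and so carries cyano in place of methyl on an aromatic carbon, the same difference reading 4-methylphenyl to 4-cyanophenyl. Within the data shown here, no measured compound changes that group, so the one measured step bears on this change only weakly. Among the measured compounds shown here, with the small step to compound 2 (a 1.4-fold lower number from compound 1 to compound 2 (0.16 log units; within the scatter)) as the sole guide, no step beyond the scatter is expected in this assay and no firm direction can be given. The expected step (a 1.2-fold lower number from compound 1 to compound 3 (0.08 log units; within the scatter)) therefore stays within the scatter. Compound 3 is estimated at 70000 nM with an expected range (30000 nM to 150000 nM).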

Compound 3, half-maximal inhibitory concentration: 76500 nM
Estimate against measurement, compound 3: 1.1-fold (0.04 log units) below, and the stated range covers the measured number.
By their numbers in this assay, from the lowest: compounds 2, 3 and 1 (each within the scatter of the next).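

In this assay, within the data shown here, the new step is the first one measured on the 4-methylphenyl group, and cyano in place of methyl, on the aromatic carbon para to a large group, gives a 1.1-fold lower number from compound 1 to compound 3 (0.04 log units; within the scatter), so compound 1 and compound 3 cannot be told apart. This position therefore accepts a group with one more heavy atom, a triple bond and a hydrogen-bond acceptor without any step beyond the scatter, a point that the earlier step, made elsewhere on the shared core, could not address. No measured information on these compounds offers an account of this result.

Going by these compounds, only methyl and cyano have been compared at this position, so it remains open whether an amine, a carboxylic acid, a halogen such as chlorine or a longer alkyl chain there would give a step beyond the scatter in this assay. Since compounds 1, 2 and 3 all lie within the scatter of the next, neither of the two places changed so far can yet be linked to a real difference in this series.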